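A New Chain End on Compound 3

This account rests on a few compounds, and the source may have more. Where it says the series, first, only, none or still open, it means among the compounds named here.

In an ADME assay on BJ cells (Homo sapiens) for cytotoxicity, with a stated time of 72 h (on this read-out higher numbers stand for an effect only at larger amounts of compound and lower numbers for an effect already at smaller amounts), compound 1 `C=C[C@@](C)(/C=C/c1ccc(OC)cc1)CCC=C(C)C` gives > 36600 nM as a limit of the assay. Compound 2 `C=C[C@](C)(CCCC(C)C)CCc1ccc(O)cc1` gives > 36600 nM as a limit as well. Compound 3 `C=C[C@@](C)(/C=C/c1ccc(O)cc1)CCC1OC1(C)C` gives > 36600 nM as a limit too, so it shares the position of the whole set the limit of > 36600 nM in this assay, at which 3 of the 3 values shown sit, and has no number of its own. For the measured compounds named here, compound 4 `C=C[C@@](C)(/C=C/c1ccc(O)cc1)CC/C=C/C(=O)OCC` has 2-(ethoxycarbonyl)ethenyl in place of 3,3-dimethyloxiran-2-yl on a saturated chain carbon, three bonds along the chain from two double-bonded chain carbons as its one change. Going by the values given here, no measured step shows what such a change does. No step beyond the usual scatter is expected, in either direction, and the estimated outcome is a number no higher from compound 3 to compound 4 (the limit leaves the size open) in this comparison. Compound 4 is estimated at 36600 nM with an expected range of 15000 nM to 60000 nM in the measurement to come.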

Compound 4, half-maximal effective concentration: > 36600 nM
Compound 4 gave a limit, no number; the forecaster's own chance of this, stated with the estimate: 75%; the middle value lies on the limit itself.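

Compound 3 and compound 4 both give only a limit in this assay, so no step can be read between them: the limit of > 36600 nM in this assay, at which 4 of the 4 values shown sit.

The compounds shown leave open how compound 4 truly compares with compound 3 in this assay.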